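A few compounds are considered here, and "the series" means these few. Any claim that something is new, unique, unknown or untested is made for them only; others in the source may bear on it.

Measured so far in a functional assay on HCT-8 cells (Homo sapiens) for cytotoxicity; on this read-out lower numbers stand for an effect already at smaller amounts and higher numbers for an effect only at larger amounts of compound:
- compound 1 `COC1=C(C)C(=O)/C(=C(O)/C=C/c2ccc(Br)cc2)C(=O)C1(C)C`: 7.4 ug/mL
- compound 2 `COC1=C(C)C(=O)/C(=C(O)/C=C/c2ccc(OC)cc2)C(=O)C1(C)C`: 5.6 ug/mL

With only these two numbers, compound 2 at 5.6 ug/mL stands within the scatter of compound 1, so the pair gives no ranking.

Compound 3 `COC1=C(C)C(=O)/C(=C(O)/C=C/c2cccc(OC)c2)C(=O)C1(C)C` is the next member: 3-methoxyphenyl in place of 4-methoxyphenyl on a double-bonded chain carbon bound to a double-bonded chain carbon.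

Among the compounds with values here, the only measured step is a 1.3-fold lower number from compound 1 to compound 2 (0.12 log units; within the scatter), for methoxy in place of bromo on an aromatic carbon. Within the data shown here, it stays within the scatter, but it is only indirect evidence, and no measured pair tests this kind of change. No shift beyond the scatter is therefore expected in this assay. The expected step is a 1.1-fold higher number from compound 2 to compound 3 (0.03 log units; within the scatter). For compound 3 the estimated value is 6 ug/mL, with an expected range from 2.8 ug/mL to 13 ug/mL.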

Compound 3, concentration for half-maximal effect: 2.9 ug/mL
For compound 3 the middle estimate is 2.1-fold (0.32 log units) above the measured one; low and high end bracket the measured number.
By their numbers in this assay, from the lowest: compounds 3, 2 and 1 (each within the scatter of the next, the first and the last beyond it).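

In this assay, 3-methoxyphenyl in place of 4-methoxyphenyl on a double-bonded chain carbon bound to a double-bonded chain carbon gives a 1.9-fold lower number from compound 2 to compound 3 (0.29 log units; within the scatter) and is the only direct test of this change, so the two methoxy isomers remain unseparated. Within the data shown here, the replacement of 4-bromophenyl by 3-methoxyphenyl at the same place gives a 2.6-fold lower number from compound 1 to compound 3 (0.41 log units; beyond the scatter) and is the only step so far that lies beyond the scatter, though it alters both the substituent and its ring position. No available measurement accounts for either step.

The compounds shown do not settle whether the substituent or its ring position carries that step, as 3-bromophenyl would be needed to separate them. Also open, as far as these compounds go, is whether an amine, a carboxylic acid or a longer chain in place of methoxy on the aromatic ring would move the number beyond the scatter.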